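Chain shortening from compound 2 to compound 3

The source may hold more compounds than are shown below. What is called first, only, known or untested is meant among the compounds shown, and "the series" means these compounds.

- compound 1 (`CCCCCCCC#Cc1cc2cn(COCCO)c(=O)nc2o1`): > 50000 nM (a limit)
- compound 2 (`CCCCCCCCCCCc1cc2cn(COCCO)c(O)nc-2n1`): 41000 nM

Within the data shown here, in a functional assay on HEL cells (Homo sapiens) (on this read-out higher numbers stand for lower toxicity in this test and lower numbers for higher toxicity in this test), compound 2 gives 41000 nM as the only actual number so far. Compound 1 gives only a limit (> 50000 nM).

Compound 3 (`CCCCc1cc2cn(COCCO)c(O)nc-2n1`) is compound 2 with hydrogen in place of heptyl on a saturated chain carbon, four bonds along the chain from an aromatic carbon. The same difference reads as octyl to methyl.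

Among the measured compounds shown here, no measured step covers this change, so the expectation is tentative. With compound 2 at 41000 nM in this assay a small move toward lower toxicity is expected, not clearly beyond the scatter. A reading reported only as a limit is quite possible for compound 3. The expected step is a 1.5-fold higher number from compound 2 to compound 3 (0.17 log units; within the scatter) in this assay here. For compound 3 the estimated value is 60000 nM (30000 nM to 150000 nM).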

Compound 3, half-maximal cytotoxic concentration: > 200000 nM
Compound 3 ended at the assay's limit; the forecaster's own chance of this, stated with the estimate: 60%; at least 3.3-fold (0.52 log units) between middle value and limit.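

Hydrogen in place of heptyl on a saturated chain carbon, four bonds along the chain from an aromatic carbon, gives an at least 4.8-fold higher number from compound 2 to compound 3 (0.68 log units; beyond the scatter) in this assay. Among these compounds, this is the first measured step at this position of the series, and it shows that the read-out responds to the length of this chain, with the shorter chain of compound 3 going with lower toxicity in this test. The size of the step is only a lower bound, since compound 3 reads as a limit and not as a number: the limit of > 200000 nM in this assay, at which 1 of the 3 values shown sits.

The compounds shown leave open whether the number climbs steadily or abruptly across chain lengths between those of compound 2 and compound 3, and how far past its limit compound 3 lies. Going by these compounds, how a chain ending in an amine or a carboxylic acid would read at this position in this assay also stays open.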